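The source may hold more compounds than are shown below. What is called first, only, known or untested is meant among the compounds shown, and "the series" means these compounds.

Measured so far in a functional assay on A549 cells (Homo sapiens) for antiproliferative activity, read by MTT assay, with a stated time of 48 h; on this read-out higher numbers stand for weaker inhibition and lower numbers for stronger inhibition:
Compound 1 `N#Cc1nc2c(-c3nc4ccccc4[nH]3)c(N)n(CCO)c2nc1C#N`: > 50000 nM, a limit of the assay.
Compound 2 `CN(C)CCCn1c(N)c(-c2nc3ccccc3[nH]2)c2nc(C#N)c(C#N)nc21`: 10400 nM.

In this assay, among the compounds with values here, compound 2, at 10400 nM, holds the only actual number. The sole other result is a limit: the limit of > 50000 nM in this assay, at which 1 of the 2 values shown sits. Compound 3 `CCCCn1c(N)c(-c2nc3ccccc3[nH]2)c2nc(C#N)c(C#N)nc21` has not yet been measured. It carries butyl where compound 2 carries 3-(dimethylamino)propyl, that is, methyl in place of dimethylamino on a saturated chain carbon, three bonds along the chain from an aromatic nitrogen. Within the data shown here, one measured step bears on this, and only indirectly: an at least 4.8-fold lower number from compound 1 to compound 2 (0.68 log units; beyond the scatter), with (dimethylamino)methyl in place of hydroxy. Compound 3 gives up the dimethylamino group that compound 2 gained in that step, so a modest move back towards higher numbers is expected, and a reading at the limit remains possible. The expected change is a 2.1-fold higher number from compound 2 to compound 3 (0.33 log units; beyond the scatter). Compound 3 is estimated at 22000 nM, with an expected range from 8000 nM to 50000 nM.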

Compound 3, half-maximal inhibitory concentration: > 50000 nM
Compound 3 was reported as a limit (the forecaster's own chance of this, stated with the estimate: 25%); at least 2.2-fold (0.35 log units) between middle value and limit.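

Turning 3-(dimethylamino)propyl into butyl gives an at least 4.8-fold higher number from compound 2 to compound 3 (0.68 log units; beyond the scatter) in this assay. The earlier step had set a dimethylamino-bearing chain against a shorter hydroxy-bearing one, so it could not separate the amine from the change in chain; here the chain stays and only the dimethylamino group gives way to methyl, and the lower number of compound 2 is lost with it. Compound 1 and compound 3 both stand at the assay limit, so the step joining them cannot be read: the limit of > 50000 nM in this assay, at which 2 of the 3 values shown sit.

Going by these compounds, whether another amine, such as diethylamino or a primary amine, would serve at the chain end as dimethylamino does remains open. So does the effect of a shorter or longer chain carrying the dimethylamino group.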